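This account rests on a few compounds, and the source may have more. Where it says the series, first, only, none or still open, it means among the compounds named here.

Compound 3 `CC(=O)OC[C@H]1CN(c2ccc(-n3cc(-c4ccccn4)cn3)c(F)c2)C(=O)O1` gives 373000 nM in a physicochemical assay for solubility, read by HPLC, with a stated time of 24 h (on this read-out lower numbers stand for lower solubility and higher numbers for higher solubility), the highest of three numbers. Compound 1 `O=C1O[C@@H](CO)CN1c1ccc(-n2cc(-c3ccccn3)cn2)c(F)c1` gives 56400 nM, and compound 2 `O=C1O[C@@H](CN2CCCCC2)CN1c1ccc(-n2cc(-c3ccccn3)cn2)c(F)c1` gives 219000 nM. Compound 4 `O=CNC[C@H]1CN(c2ccc(-n3cc(-c4ccccn4)cn3)c(F)c2)C(=O)O1` differs from compound 3 by formylamino in place of acetoxy on a saturated chain carbon bound to a saturated ring carbon. For the measured compounds named here, two measured steps bear on this change: a 6.6-fold higher number from compound 1 to compound 3 (0.82 log units; beyond the scatter), and a 3.9-fold higher number from compound 1 to compound 2 (0.59 log units; beyond the scatter); the gap a 1.7-fold higher number from compound 2 to compound 3 (0.23 log units; within the scatter) is within the scatter. Replacing the acetoxy group with a group that, like the hydroxy group of compound 1, carries a hydrogen-bond donor is expected to move the number back toward compound 1, so a modest fall is expected, a 3.7-fold lower number from compound 3 to compound 4 (0.57 log units; beyond the scatter). Compound 4 is therefore estimated at 100000 nM, with a range from 40000 nM to 250000 nM.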

Compound 4, solubility: 217000 nM
The estimate for compound 4 lay 2.2-fold (0.34 log units) below the measured number; the range from low to high includes it.
By their numbers in this assay, from the lowest: compound 1; then compounds 4, 2 and 3 (each within the scatter of the next).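

At this saturated chain carbon, formylamino reads level with acetoxy (a 1.7-fold lower number from compound 3 to compound 4 (0.24 log units; within the scatter)) and with piperidin-1-yl (a 1.0-fold lower number from compound 2 to compound 4 (0.00 log units; within the scatter)) in this assay. Only compound 1, with its hydroxy group, stands apart (a 3.8-fold higher number from compound 1 to compound 4 (0.59 log units; beyond the scatter)), so the hydrogen-bond donor of formylamino does not by itself bring the number back to that of compound 1. Nothing available explains why hydroxy differs from the other three groups. On these data alone, it remains open whether a primary amine or a carboxylic acid at this place would group with compound 1 or with the other three.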